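The source may report more compounds than this note shows. Statements on the series, on what has been measured and on what is new or still open speak of the compounds shown alone.

Compound 1 `COC(=O)N[C@H](C(=O)NN(CCC[C@@](O)(Cc1ccccc1)C(=O)N[C@H]1c2ccccc2C[C@H]1O)Cc1ccc(Br)cc1)C(C)(C)C` was examined in an ADME assay on MT4 cells (Homo sapiens) for cytotoxicity; on this read-out higher numbers stand for lower toxicity in this test and lower numbers for higher toxicity in this test. In this assay compound 1 gives > 10000 nM, which is a limit of the assay rather than a measured number. Compound 2 `COC(=O)N[C@H](C(=O)NN(CCC[C@@](O)(Cc1ccccc1)C(=O)N[C@H]1c2ccccc2C[C@H]1O)Cc1ccc(-n2ccnc2)cc1)C(C)(C)C` carries 1H-imidazol-1-yl in place of bromo on an aromatic carbon. In this assay compound 2 gives > 10000 nM, again a limit. Compound 3 `COC(=O)N[C@H](C(=O)NN(CCC[C@@](O)(Cc1ccccc1)C(=O)N[C@H]1c2ccccc2C[C@H]1O)Cc1ccc(-c2cn3ccsc3n2)cc1)C(C)(C)C` carries a different group at that aromatic carbon. In this assay compound 3 gives > 10000 nM, also a limit. The step that the two limits leave unreadable from compound 1 to compound 2 and the step that the two limits leave unreadable from compound 1 to compound 3 therefore cannot be sized, because all three values sit at the limit of > 10000 nM in this assay, at which 3 of the 3 values shown sit. Compound 4 `COC(=O)N[C@H](C(=O)NN(CCC[C@@](O)(Cc1ccccc1)C(=O)N[C@H]1c2ccccc2C[C@H]1O)Cc1ccc(-c2ccccc2)cc1)C(C)(C)C` differs from compound 1 by phenyl in place of bromo on an aromatic carbon. Both other replacements at this aromatic carbon left the read-out at the limit, so no shift beyond the scatter is expected here; the expected step is a step that the limit leaves unreadable from compound 1 to compound 4. The estimate for compound 4 is 20000 nM, between 8000 nM and 60000 nM, and it is expected that this assay will again report only a limit.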

Compound 4, half-maximal cytotoxic concentration: 7500 nM
Estimate against measurement, compound 4: 2.7-fold (0.43 log units) above; the measured number lies below the stated range.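

In this assay, within the data shown here, compound 4 gives 7500 nM, the first real number in this set. Phenyl is the one group shown at this aromatic carbon that brings the read-out under the limit: the limit of > 10000 nM in this assay, at which 3 of the 4 values shown sit. Set against the earlier compounds, this gives an at least 1.3-fold lower number from compound 1 to compound 4 (0.12 log units; that floor lies within the scatter), an at least 1.3-fold lower number from compound 3 to compound 4 (0.12 log units; that floor lies within the scatter) and an at least 1.3-fold lower number from compound 2 to compound 4 (0.12 log units; that floor lies within the scatter). Each of these is only a floor, so the true gap could be small or large, and these steps alone do not establish that compound 4 is more toxic to the cells.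

Going by these compounds, how far the other three compounds actually lie from compound 4 stays unknown, as their limits give no number. Also open, on these data alone, is what an amine or a carboxylic acid at this aromatic carbon would do to the read-out.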